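The compounds below may be only part of what the source reports. "The series", "measured", "known", "first", "only" and "open" are said of these compounds alone.

Of the compounds shown here, two built on one shared core have been measured in a functional assay for inhibition, tested at 100 ug/mL; on this read-out lower numbers stand for a weaker effect and higher numbers for a stronger effect at the one concentration tested. Compound 1 `Cc1cc(O)c(C(C)C)cc1-c1cc(-c2cccs2)c(C#N)c(=O)[nH]1` carries a thiophen-2-yl group on the core, and compound 1 gives 68%. Compound 2 `COc1ccc(-c2cc(-c3cc(C(C)C)c(O)cc3C)[nH]c(=O)c2C#N)cc1` carries a 4-methoxyphenyl group instead, and compound 2 gives 54%. That single swap produced a number 14 percentage points lower from compound 1 to compound 2 (beyond the scatter). On the two numbers available, compound 2 therefore stands lowest, with compound 1 higher by more than the scatter.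

Compound 3 `COc1ccc(-c2cc(-c3cc(C(C)C)c(O)cc3C)[nH]c(=O)c2C#N)cc1OC` has not yet been measured. It differs from compound 2 in one place: methoxy in place of hydrogen on an aromatic carbon. Cut one bond further out, the change reads 4-methoxyphenyl to 3,4-dimethoxyphenyl.

Going by the values given here, no measured step adds a methoxy group to this ring. Among the compounds with values here, the one step known, a number 14 percentage points lower from compound 1 to compound 2 (beyond the scatter), exchanged the whole ring and was modest in size; a second methoxy on an otherwise unchanged ring is a smaller alteration than that. The expected step of a number 4 percentage points lower from compound 2 to compound 3 (within the scatter) is therefore small, probably within the scatter, with a slight lean downward. For compound 3 the estimate in this assay is 50%, with a range from 30% to 70%.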

Compound 3, a percentage reported as inhibition, at one concentration (the size of the read-out at that concentration, not a potency): 61%
Estimate against measurement, compound 3: 11 percentage points below, and the stated range covers the measured number.
By their numbers in this assay, from the lowest: compounds 2, 3 and 1 (each within the scatter of the next, the first and the last beyond it).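

In this assay, going by these compounds alone, methoxy in place of hydrogen on the aromatic carbon ortho to the existing methoxy group gives a number 7 percentage points higher from compound 2 to compound 3 (within the scatter), the first reading for a second methoxy on this ring, and one that cannot be told apart from repeat scatter. Replacing thiophen-2-yl with 3,4-dimethoxyphenyl gives a number 7 percentage points lower from compound 1 to compound 3 (within the scatter), so this swap stays within the scatter, whereas the earlier swap to 4-methoxyphenyl went beyond it. No separate measurement bears on these results, so the numbers alone cannot say what lies behind them.

On these data alone, it remains open whether an amine, a carboxylic acid or a longer chain such as ethoxy at this same place on the ring would produce a step beyond the scatter. Each compound was also read at one concentration only, so these percentages describe the size of the effect at that concentration and leave the potencies of the three compounds unknown.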